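The source may report more compounds than this note shows. Statements on the series, on what has been measured and on what is new or still open speak of the compounds shown alone.

Working notes on the series. The shared core of compound 1 `O=C(Nc1ncc(Cc2ccc(F)cc2)s1)c1ccc(Cl)cc1Cl` is carried with different substituents through compounds 2 and 3. In an ADME assay on HepG2 2.2.15 cells (Homo sapiens) for cytotoxicity (a lower number here means that less compound is tolerated, a higher number that more compound is tolerated), compound 1 gives only a limit of the assay, > 50000 nM, not a number. Compound 2 `Clc1ccc(C(Oc2ccc3cc(Br)ccc3c2)c2cnc(NCC3CCOCC3)s2)cc1` has no numerical read-out in this assay; it is recorded as "not toxic" (no number reported), so its position can be stated only as lacking any sign of cell damage in the range examined. The evidence at hand is thin: the limit of > 50000 nM in this assay, at which 1 of the 2 values shown sits. Compound 3 `O=C(Nc1ncc(C(Oc2ccc3cc(Br)ccc3c2)c2ccc(Cl)cc2)s1)c1ccc(F)cc1` differs from compound 2 at one place: (4-fluorophenyl)carbonyl in place of (oxan-4-yl)methyl on a nitrogen on an aromatic ring. Going by the values given here, no measured step between compounds is available to size the effect of this change, so no step beyond the scatter is expected in either direction; the series so far shows only tolerance. For compound 3 the half-maximal cytotoxic concentration is expected to be 50000 nM, with a likely range from 20000 nM to 120000 nM, most probably again reported as a limit rather than a number.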

Compound 3, half-maximal cytotoxic concentration: "not toxic" (no number reported)
Nothing numeric was reported for compound 3; the estimate stays without a comparison.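

Compound 2 and compound 3 are both recorded as "not toxic" without a number, so no step can be read between them. Going by these compounds, how far (4-fluorophenyl)carbonyl in place of (oxan-4-yl)methyl shifts tolerance in this assay, if at all, stays open.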